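Rearranging a prenyl-derived side chain on a flavanone core

The source may hold more compounds than are shown below. What is called first, only, known or untested is meant among the compounds shown, and "the series" means these compounds.

Compound 1, `COC(C)(C)/C=C/C/C(C)=C/Cc1c(O)ccc2c1O[C@H](c1ccc(O)cc1)CC2=O`, was tested in a functional assay on KB cells (Homo sapiens) for cytotoxicity, read by MTT assay (on this read-out lower numbers stand for stronger inhibition and higher numbers for weaker inhibition), and gave only a limit of the assay, > 10000 nM, rather than a number. Compound 2, `C=C(CCC=C(C)C)C(O)Cc1c(O)ccc2c1O[C@H](c1ccc(O)cc1)CC2=O`, shares the core and in this assay likewise reached only a limit, > 10000 nM. So compound 1 stands at the edge of what this assay can resolve, and nothing measured here sits anywhere else: the limit of > 10000 nM in this assay, at which 2 of the 2 values shown sit. Compound 3, `COC(C=C(C)C)C/C(C)=C/Cc1c(O)ccc2c1O[C@H](c1ccc(O)cc1)CC2=O`, has not yet been measured. It keeps the same atoms as compound 1, joined differently: 1-methoxy-3-methylbut-2-en-1-yl in place of 3-methoxy-3-methylbut-1-en-1-yl on a saturated chain carbon bound to a double-bonded chain carbon. The side chain still carries a single methoxy group and one double bond outside the aromatic rings, only in swapped positions along the chain. Going by the values given here, with no measured step available and both known compounds at the limit, the step from compound 1 to compound 3 is expected to be a step that the limit leaves unreadable from compound 1 to compound 3, that is none beyond the usual scatter. Compound 3 is therefore estimated at 15000 nM, with a likely range from 5000 nM to 50000 nM, and most probably this assay will again report only a limit.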

Compound 3, half-maximal inhibitory concentration: > 10000 nM
Compound 3: only a limit was reported; the forecaster's own chance of this, stated with the estimate: 75%; the middle value does not contradict the limit.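

Going by these compounds alone, compound 1 and compound 3 both reached only a limit in this assay, so moving the methoxy group and double bond along the side chain gives no step that can be read. The compounds shown leave open how any of these side chains would rank against one another, as all of them sit at the same limit: the limit of > 10000 nM in this assay, at which 3 of the 3 values shown sit.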